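From isopropyl to 4-(trifluoromethoxy)phenyl: will the half-life move?

The source may hold more compounds than are shown below. What is called first, only, known or untested is meant among the compounds shown, and "the series" means these compounds.

Measured in an ADME assay (liver, Mus musculus) for metabolic stability, using microsomes; a higher number here means that the compound lasts longer, a lower number that the compound disappears faster:
- Compound 1 `CCc1nc2cc(Cl)ccn2c1C(=O)NCc1ccc(-c2ccc[nH]2)cc1`: 0.18 h
- Compound 2 `CCc1nc2cc(Cl)ccn2c1C(=O)NCc1ccc(N2CCN(C(C)C)CC2)cc1`: 0.148 h

Going by the values given here, with only two numbers in hand, compound 2 cannot be told apart from compound 1, since the gap lies within the scatter. The next compound, compound 3 `CCc1nc2cc(Cl)ccn2c1C(=O)NCc1ccc(N2CCN(c3ccc(OC(F)(F)F)cc3)CC2)cc1`, places 4-(trifluoromethoxy)phenyl in place of isopropyl on an amine nitrogen in a ring.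

One measured step offers guidance: a 1.2-fold lower number from compound 1 to compound 2 (0.09 log units; within the scatter). It exchanged 1H-pyrrol-2-yl on an aromatic carbon for 4-isopropylpiperazin-1-yl, so it did not test the amine nitrogen now being changed. It is weak evidence, and the range must stay wide. The expected change is a 1.4-fold higher number from compound 2 to compound 3 (0.13 log units; within the scatter), which means no shift beyond the scatter is expected. For compound 3 the estimated half-life in this assay is 0.2 h, with an expected range from 0.08 h to 0.6 h.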

Compound 3, half-life: > 1 h
Compound 3 ended at the assay's limit; the forecaster's own chance of this, stated with the estimate: 5%; at least 5.0-fold (0.69 log units) between middle value and limit.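

In this assay, the group on the amine nitrogen in the ring turns out to matter: putting 4-(trifluoromethoxy)phenyl in place of isopropyl gives an at least 6.7-fold higher number from compound 2 to compound 3 (0.82 log units; beyond the scatter). The earlier step changed a different place, an aromatic carbon, and stayed within the scatter, so this is the first change shown that moves the half-life beyond it. The true size of this step remains unknown, as compound 3 stands at a limit of the assay and not at an exact number: the limit of > 1 h in this assay, at which 1 of the 3 values shown sits.

The new group brings an aromatic ring and a trifluoromethoxy group together, and this one step does not separate what each contributes to the longer half-life. On these data alone, how a plain phenyl or an acetyl group on the same nitrogen would compare stays open.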